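A few compounds are considered here, and "the series" means these few. Any claim that something is new, unique, unknown or untested is made for them only; others in the source may bear on it.

Of the compounds shown here, three built on the same core have been tested in an ADME assay on Vero cells (Chlorocebus sabaeus) for cytotoxicity; a lower number here means a stronger inhibitor, a higher number a weaker inhibitor. Compound 1 `O=C1c2cccnc2C(=O)N1c1ccc(Cl)cc1` gives 92000 nM in this assay. Compound 3 `C[C@@H](c1ccccc1)N1C(=O)c2nccnc2C1=O` gives 85000 nM in this assay. Compound 2 `COc1ccc(CN2C(=O)c3nccnc3C2=O)cc1OC` is reported in this assay at > 100000 nM, which is a limit of the assay and not a number. That reading is the limit of > 100000 nM in this assay, at which 1 of the 3 values shown sits. Where compound 2 stands is thus only known as a limit, and its neighbours in the set sit close to that same region, so no compound here can be set apart from another beyond the usual scatter.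

Compound 4 `COc1ccc(CN2C(=O)c3nccnc3C2=O)cc1` has not yet been measured. It differs from compound 2 in one place: hydrogen in place of methoxy on an aromatic carbon. Going by the values given here, no measured pair in this set shows what such a change does, and compound 2 carries only a limit, so no exact step from it can be counted. With every measured reading in this set falling together at weak inhibition, a step of no size beyond the scatter is expected, namely a number no higher from compound 2 to compound 4 (the limit leaves the size open). For compound 4 the estimate in this assay is 100000 nM, expected to lie between 50000 nM and 200000 nM.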

Compound 4, half-maximal inhibitory concentration: > 100000 nM
Compound 4 gave a limit, no number; the forecaster's own chance of this, stated with the estimate: 55%; the middle value sits exactly at the limit.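

No step from compound 2 to compound 4 can be read in this assay, since each carries only a limit and not a number: the limit of > 100000 nM in this assay, at which 2 of the 4 values shown sit.

The compounds shown leave open what hydrogen in place of methoxy on an aromatic carbon does to the reading, and how weak compound 2 and compound 4 actually are as inhibitors.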